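The source may report more compounds than this note shows. Statements on the series, on what has been measured and on what is new or still open speak of the compounds shown alone.

Measured so far:
compound 1, `NC1CCC(Nc2nc(NCc3ccc(-c4ccco4)cc3)c3ncn(C4CCCC4)c3n2)CC1`, giving 71 nM in a functional assay on HeLa cells (Homo sapiens) for inhibition, with a stated time of 72 h; a lower number here means a stronger inhibitor, a higher number a weaker inhibitor 
compound 2, `CC(C)(O)CNc1nc(NCc2ccc(-c3ccco3)cc2)c2ncn(C3CCCC3)c2n1`, giving 14800 nM in this assay 
compound 3, `NC1CCC(Nc2nc(NCc3ccc(-c4ccccc4)nc3)c3ncn(C4CCCC4)c3n2)CC1`, giving 114 nM in this assay 

Compound 2 carries the highest number of the three in this assay; the value of compound 3 lies well under it, and the value of compound 1 lower still. For the measured compounds named here, the one step that reaches compound 2 is a 210-fold higher number from compound 1 to compound 2 (2.32 log units; beyond the scatter), a change on a nitrogen on an aromatic ring that the shared core carries. Compound 4, `CC(C)(O)CNc1nc(NCc2ccc(-c3ccco3)nc2)c2ncn(C3CCCC3)c2n1`, keeps the 2-hydroxy-2-methylpropyl of compound 2 and changes the other side instead: 6-(furan-2-yl)pyridin-3-yl in place of 4-(furan-2-yl)phenyl on a saturated chain carbon bound to a nitrogen on an aromatic ring.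

The step that bears on this change is a 1.6-fold higher number from compound 1 to compound 3 (0.21 log units; within the scatter), where a pyridine ring likewise took the place of the carbon-only six-membered ring at the same place. That step stayed within the scatter. The change from compound 2 to compound 4 is smaller, since the furan-2-yl is retained, so no step beyond the scatter is expected in this assay, in either direction. Compound 4 is therefore estimated at 18000 nM, within a range of 6000 nM to 50000 nM, which would mean an expected step of a 1.2-fold higher number from compound 2 to compound 4 (0.09 log units; within the scatter).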

Compound 4, half-maximal inhibitory concentration: 667 nM
Estimate against measurement, compound 4: 27-fold (1.43 log units) above, outside the stated range (below it).
By their numbers in this assay, from the lowest: compounds 1 and 3 (each within the scatter of the next); then compound 4; then compound 2.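

In this assay, 6-(furan-2-yl)pyridin-3-yl in place of 4-(furan-2-yl)phenyl on a saturated chain carbon bound to a nitrogen on an aromatic ring gave a 22-fold lower number from compound 2 to compound 4 (1.35 log units; beyond the scatter), which shows that, with 2-hydroxy-2-methylpropyl on the other side, this change at this place is far from silent. For the compounds shown here, the only earlier step at this place, a 1.6-fold higher number from compound 1 to compound 3 (0.21 log units; within the scatter), stayed within the scatter, but it carried 4-aminocyclohexyl and also replaced the furan-2-yl with phenyl, so it could not show what the ring nitrogen alone does with the furan-2-yl kept. Nothing available accounts for the size of the new step.

The compounds shown leave open whether 6-(furan-2-yl)pyridin-3-yl would lower the number to a similar extent with 4-aminocyclohexyl in the other place, which would tell whether the two places act independently. From the compounds shown here alone, it is also open whether a straight chain ending in a primary amine, or one ending in a carboxylic acid, in place of 2-hydroxy-2-methylpropyl would bring the number nearer that of the aminocyclohexyl compounds.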